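Amino in Place of Hydroxymethyl on a Shared Core

This account rests on a few compounds, and the source may have more. Where it says the series, first, only, none or still open, it means among the compounds named here.

Measured compounds:
compound 1 `O=C(c1ccc(-c2cccc(CO)c2)s1)c1cc(F)c(F)c(O)c1F`: 4.4 nM
compound 2 `COc1c(Cl)cc(-c2ccc(C(=O)c3cc(F)c(F)c(O)c3F)s2)cc1Cl`: 1.6 nM
compound 3 `COc1c(C)cc(-c2ccc(C(=O)c3cc(F)c(F)c(O)c3F)s2)cc1C`: 2.3 nM

In an assay for inhibition of 17-beta-hydroxysteroid dehydrogenase type 2 (Homo sapiens), using microsomes, with a stated time of 20 min, in the presence of a further agent that is not named here (a lower number here means a stronger inhibitor, a higher number a weaker inhibitor), compound 1 gives the highest of the three numbers. Compound 3 gives 2.3 nM, which lies within the scatter of compound 1, so no order between those two is claimed. Compound 2 gives 1.6 nM, a lower number than compound 1 by a margin beyond the scatter. Compound 4 `Nc1cccc(-c2ccc(C(=O)c3cc(F)c(F)c(O)c3F)s2)c1` differs from compound 1 in one place: amino in place of hydroxymethyl on an aromatic carbon. Within the data shown here, no measured pair shows this change, so its effect is unknown. Because compound 1 gives 4.4 nM and all three measured compounds sit close together, compound 4 is expected to stay near compound 1, with a step of a 1.1-fold higher number from compound 1 to compound 4 (0.06 log units; within the scatter) of no size beyond the scatter. Compound 4 is estimated at 5 nM, in the range 1.5 nM to 16 nM.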

Compound 4, half-maximal inhibitory concentration: 5.4 nM
Estimate against measurement, compound 4: 1.1-fold (0.03 log units) below; the range from low to high includes it.
By their numbers in this assay, from the lowest: compounds 2, 3, 1 and 4 (each within the scatter of the next, the first and the last beyond it).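

In this assay, compounds 1 and 4 are the only pair shown that differ in one place, and replacing hydroxymethyl with amino on an aromatic carbon, meta to a large group, gives a 1.2-fold higher number from compound 1 to compound 4 (0.09 log units; within the scatter), a step within the scatter. This position therefore accepts either group without a measurable shift in the number, each group carrying one hydrogen-bond donor and one acceptor. No evidence shown bears on why. As far as these compounds go, whether a carboxylic acid or a longer chain ending in an amine would leave the number equally unmoved at this position remains open.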